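Adding a Methyl Group to the Ring of Compound 3

The source may hold more compounds than are shown below. What is called first, only, known or untested is meant among the compounds shown, and "the series" means these compounds.

Of the compounds shown here, three that share one core have been measured in a functional assay, tested at 100 ug/mL; a higher number here means a weaker effect of the compound at the concentration tested, a lower number a stronger effect. Compound 1 `CCOC(=O)C1=C(C)N(c2ccc(Cl)cc2)C=CC1c1ccccc1` gives -19.1% in this assay, and compound 2 `CCOC(=O)C1=C(C)N(c2ccc(Br)cc2)C=CC1c1ccccc1` gives -18.7%. For the measured compounds named here, the single step that can be read from these measurements, a number 0.4 percentage points higher from compound 1 to compound 2 (within the scatter), lies within the scatter. Compound 3 `COC(=O)C1=C(C)N(c2ccccc2)C=CC1c1ccccc1` gives -25.9% in this assay; this is the lowest of the three numbers, yet its gaps to compound 1 and to compound 2 are both within the scatter, so the three compounds cannot be put in any order.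

Compound 4 `COC(=O)C1=C(C)N(c2ccccc2)C=C(C)C1c1ccccc1` differs from compound 3 in one place: methyl in place of hydrogen on a double-bonded ring carbon. Going by the values given here, no measured step concerns a methyl in place of hydrogen on a double-bonded ring carbon; the only measured step changes a different part of the molecule and was itself within the scatter. The data therefore give no ground to expect a step beyond the scatter in either direction. Compound 4 is expected to give about -24% in this assay, between -45% and -3%, a step of a number 1.9 percentage points higher from compound 3 to compound 4 (within the scatter) that is estimated to stay within the scatter.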

Compound 4, a percentage reported as activity, at one concentration (the size of the read-out at that concentration, not a potency): -21.1%
The estimate for compound 4 lay 2.9 percentage points below the measured number; the measured number falls inside the stated range.
By their numbers in this assay, from the lowest: compounds 3, 4, 1 and 2 (each within the scatter of the next).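

For the compounds shown here, this is the first measured change at this double-bonded ring carbon, and in this assay putting a methyl group in place of hydrogen gives a number 4.8 percentage points higher from compound 3 to compound 4 (within the scatter), a step that lies within the scatter. At this concentration, then, the added methyl leaves the read-out indistinguishable from that of the parent with hydrogen, although this single pair cannot show how other groups would behave at the same position. No supporting measurement bears on why the step is so small.

On these data alone, whether a longer chain, an amine or a carboxylic acid on this ring carbon would produce a step beyond the scatter remains open. Also open, as far as these compounds go, is whether the same methyl would give a similarly small step if added to compound 1 or compound 2, which carry a chloro or bromo group on the aromatic ring.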